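This account rests on a few compounds, and the source may have more. Where it says the series, first, only, none or still open, it means among the compounds named here.

Compound 1 `COc1cc(Cn2cc(CNC(=O)c3cn(-c4ccccc4)nc3-c3ccccc3)nn2)cc(OC)c1`: 190 nM
Compound 2 `O=C(NCc1cn(Cc2ccc(C(F)(F)F)cc2)nn1)c1cn(-c2ccccc2)nc1-c1ccc(F)cc1`: 760 nM
Compound 3 `COc1ccc(Cn2cc(CNC(=O)c3cn(-c4ccccc4)nc3-c3ccc(F)cc3)nn2)cc1OC`: > 100000 nM, a limit of the assay

In a functional assay on MIA PaCa-2 cells (Homo sapiens) for antiproliferative activity, read by sulforhodamine B assay, with a stated time of 48 h (on this read-out lower numbers stand for stronger inhibition of growth and higher numbers for weaker inhibition of growth), compound 3 reports only a limit, so it stands at the limit of > 100000 nM in this assay, at which 1 of the 3 values shown sits, and gives no number among the three compounds. Compound 4 `COc1cc(Cn2cc(CNC(=O)c3cn(-c4ccccc4)nc3-c3ccc(F)cc3)nn2)cc(OC)c1` carries 3,5-dimethoxyphenyl in place of 3,4-dimethoxyphenyl on a saturated chain carbon bound to an aromatic nitrogen. Among the measured compounds shown here, one measured step touches this part of the molecule: an at least 130-fold higher number from compound 2 to compound 3 (2.11 log units; beyond the scatter). The 3,5-dimethoxyphenyl of compound 4 is shared with compound 1, which differs only elsewhere, and in this assay compound 1 gives 190 nM. Compound 4 is therefore expected to return into the measurable range, and its estimate is 600 nM, between 150 nM and 5000 nM, which means an expected step of an at least 160-fold lower number from compound 3 to compound 4 (2.22 log units; beyond the scatter).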

Compound 4, concentration for 50% growth inhibition: 190 nM
Estimate against measurement, compound 4: 3.2-fold (0.50 log units) above; the measured number falls inside the stated range.
By their numbers in this assay, from the lowest: compounds 1 and 4 (each within the scatter of the next); then compound 2. At a limit, above all of these: compound 3.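

In this assay, the same atoms joined differently on a saturated chain carbon bound to an aromatic nitrogen give an at least 520-fold lower number from compound 3 to compound 4 (2.72 log units; beyond the scatter), and the arrangement of the two methoxy groups alone separates these compounds. Compound 3 reports a limit of the assay, which makes this step a bound: the limit of > 100000 nM in this assay, at which 1 of the 4 values shown sits.

3,5-Dimethoxyphenyl in place of 4-(trifluoromethyl)phenyl gives a 4.0-fold lower number from compound 2 to compound 4 (0.60 log units; beyond the scatter), while fluoro in place of hydrogen on an aromatic carbon gives no change at the digits printed from compound 1 to compound 4 (within the scatter). Going by these compounds, whether an unsubstituted phenyl or a hydroxyphenyl at this place would keep growth inhibition in the measurable range remains open.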